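This account rests on a few compounds, and the source may have more. Where it says the series, first, only, none or still open, it means among the compounds named here.

Compound 1, `O=C1CN(C2CCCC2)c2nc(Nc3ccc(N4CCCCC4)cn3)ncc2N1`, and compound 2, `CC1CCN(c2ccc(Nc3ncc4c(n3)N(C3CCCC3)CC(=O)N4)nc2)CC1`, share one core. In a functional assay on HCT-116 cells (Homo sapiens) for inhibition, read by MTT assay, with a stated time of 48 h (a higher number here means a weaker inhibitor, a lower number a stronger inhibitor), compound 1 gives > 30000 nM, which is a limit of the assay and not a number. In this assay compound 2 gives > 30000 nM, likewise a limit of the assay. The step that the two limits leave unreadable from compound 1 to compound 2 cannot be read because of the limit of > 30000 nM in this assay, at which 2 of the 2 values shown sit. Compound 3, `CCN1C(=O)CN(C2CCCC2)c2nc(Nc3ccc(N4CCC(C)CC4)cn3)ncc21`, differs from compound 2 by ethyl in place of hydrogen on an amide-type nitrogen in a ring. Going by the values given here, no measured step bears on this change, and the only anchor sits at a limit, so no direction beyond the scatter can be drawn. Compound 3 is expected at 40000 nM, within 8000 nM to 150000 nM. The expected step is a step that the limit leaves unreadable from compound 2 to compound 3.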

Compound 3, half-maximal inhibitory concentration: 19100 nM
The estimate for compound 3 lay 2.1-fold (0.32 log units) above the measured number; measured number inside the range.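

In this assay compound 3, at 19100 nM, is the only compound shown whose value is a number and not a limit. Ethyl is accepted on the amide-type nitrogen in the ring, with an at least 1.5-fold lower number from compound 2 to compound 3 (0.19 log units; that floor lies within the scatter) as the step for this change. Only a floor can be given for that step, and the floor itself does not go beyond the scatter: the limit of > 30000 nM in this assay, at which 2 of the 3 values shown sit.

Still open, from the compounds shown here alone, is whether a longer chain such as propyl, or a chain ending in an amine, on the same nitrogen would move the number further from the limit.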